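Moving the ring nitrogen on a triazole-linked pyridine

This account rests on a few compounds, and the source may have more. Where it says the series, first, only, none or still open, it means among the compounds named here.

The two measured compounds share a core and differ only in the aromatic group on the triazole nitrogen. Compound 1 `CC(C)(C)OC(=O)N1CC=C(c2cn(-c3cccc(F)c3)nn2)CC1` carries a 3-fluorophenyl there and, in a functional assay on CHO cells for antagonist activity at metabotropic glutamate receptor 1 (Mus musculus), read by FLIPR and calcium flux (on this read-out higher numbers stand for weaker inhibition and lower numbers for stronger inhibition), compound 1 gives 39 nM. Compound 2 `CC(C)(C)OC(=O)N1CC=C(c2cn(-c3ccccn3)nn2)CC1` carries a pyridin-2-yl instead, and in this assay compound 2 gives 150 nM, the higher of the two numbers; the step of a 3.8-fold higher number from compound 1 to compound 2 (0.59 log units; beyond the scatter) lies beyond the scatter.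

Compound 3 `CC(C)(C)OC(=O)N1CC=C(c2cn(-c3ccncc3)nn2)CC1` is the next variation: pyridin-4-yl in place of pyridin-2-yl on an aromatic nitrogen. Going by the values given here, no measured step moves the nitrogen within the pyridine; the only step at this position, a 3.8-fold higher number from compound 1 to compound 2 (0.59 log units; beyond the scatter), swapped an entire ring and is therefore only a loose guide to the size of change this position can show. On that basis the expected step of a 1.2-fold higher number from compound 2 to compound 3 (0.08 log units; within the scatter) is small, most likely within the scatter, with the direction uncertain. In this assay compound 3 is expected to give about 180 nM, estimated between 60 nM and 600 nM.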

Compound 3, half-maximal inhibitory concentration: 1000 nM
Estimate against measurement, compound 3: 5.6-fold (0.74 log units) below; measured number outside the range, above it.
By their numbers in this assay, from the lowest: compound 1; then compound 2; then compound 3.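

In this assay, the place of the ring nitrogen within the pyridine proves to matter on its own: pyridin-2-yl and pyridin-4-yl hold the same atoms joined differently, yet exchanging them gives a modest step (a 6.7-fold higher number from compound 2 to compound 3 (0.82 log units; beyond the scatter)), the same grade as the earlier exchange of a whole ring (a 3.8-fold higher number from compound 1 to compound 2 (0.59 log units; beyond the scatter)). Replacing 3-fluorophenyl with pyridin-4-yl gives a large step (a 26-fold higher number from compound 1 to compound 3 (1.41 log units; beyond the scatter)), so among these three compounds the group on the triazole nitrogen spans a wide range, with compound 1 giving the strongest inhibition and compound 3 the weakest. Nothing available here speaks to the reason for these differences.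

The compounds shown leave open where pyridin-3-yl, the remaining isomer, would fall in this order, and whether plain phenyl would read closer to the 3-fluorophenyl of compound 1 or to the pyridines. They also leave open whether a fluorine or a methoxy group on the pyridin-4-yl ring of compound 3 would bring the number back down.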